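The source may hold more compounds than are shown below. What is called first, only, known or untested is meant among the compounds shown, and "the series" means these compounds.

Measured so far:
- compound 1 `COc1cc(/C=C/C(=O)Nc2cc3c(Nc4ccc(F)c(Cl)c4)ncnc3cc2O[C@H]2CCOC2)cc(OC)c1OC` gives 20500 nM
- compound 2 `O=C(/C=C/c1ccc(F)cc1Cl)Nc1cc2c(Nc3ccc(F)c(Cl)c3)ncnc2cc1O[C@H]1CCOC1` gives 7150 nM

Both compounds were tested in a functional assay on PC-3 cells (Homo sapiens) for cytotoxicity, read by MTT assay, with a stated time of 72 h; on this read-out lower numbers stand for stronger inhibition and higher numbers for weaker inhibition. Of these two numbers, compound 2 has the lower, 7150 nM, so it is the stronger inhibitor of the pair.

The next compound, compound 3 `O=C(/C=C/c1ccc(Br)cc1)Nc1cc2c(Nc3ccc(F)c(Cl)c3)ncnc2cc1O[C@H]1CCOC1`, has not yet been measured. It carries 4-bromophenyl in place of 2-chloro-4-fluorophenyl on a double-bonded chain carbon bound to a double-bonded chain carbon, and the full count of the change is 4-bromophenyl in place of 2-chloro-4-fluorophenyl on a double-bonded chain carbon bound to a double-bonded chain carbon.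

Among the compounds with values here, only one measured step bears on this change, because it concerns the same place: a 2.9-fold lower number from compound 1 to compound 2 (0.46 log units; beyond the scatter). That step is modest, even though 3,4,5-trimethoxyphenyl gave way to 2-chloro-4-fluorophenyl. With a single step to go on, the data do not show which way a bromine-bearing ring should move the number. In this assay, a small change with no clear direction is therefore expected, and the expected step is a 1.1-fold higher number from compound 2 to compound 3 (0.05 log units; within the scatter).

For compound 3 the estimated value is 8000 nM, with an expected range from 3000 nM to 20000 nM.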

Compound 3, half-maximal inhibitory concentration: 28200 nM
Beside the measured number, compound 3's estimate is 3.5-fold (0.55 log units) below it, outside the stated range (above it).
By their numbers in this assay, from the lowest: compound 2; then compounds 1 and 3 (each within the scatter of the next).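

In this assay, the ring on the double-bonded chain carbon can move the number in either direction: replacing 2-chloro-4-fluorophenyl with 4-bromophenyl gives a 3.9-fold higher number from compound 2 to compound 3 (0.60 log units; beyond the scatter) and so cancels the earlier gain of a 2.9-fold lower number from compound 1 to compound 2 (0.46 log units; beyond the scatter). Two rings with quite different substituents, 3,4,5-trimethoxyphenyl and 4-bromophenyl, cannot be told apart here, with a 1.4-fold higher number from compound 1 to compound 3 (0.14 log units; within the scatter) and a gap within the scatter, so among these three compounds only the 2-chloro-4-fluorophenyl ring of compound 2 stands apart, its steps to both others lying beyond the scatter. Nothing available explains why two halogen-bearing rings part ways in this way.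

Compound 2 and compound 3 differ in chlorine, fluorine and bromine at once, so it remains open which of these atoms, or which combination of them, accounts for the step. A plain phenyl ring, 4-fluorophenyl or 4-chlorophenyl would separate these atoms one at a time, while a ring bearing an amine or a carboxylic acid would show how this position responds to a very different kind of group.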